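The source may report more compounds than this note shows. Statements on the series, on what has been measured and on what is new or still open speak of the compounds shown alone.

Of the compounds shown here, three built on a shared core have been tested in a functional assay on SW-620 cells (Homo sapiens) for inhibition, read by MTT assay, with a stated time of 72 h; a higher number here means a weaker inhibitor, a lower number a stronger inhibitor. Compound 1 `O=C1O[C@H]([C@@H](O)Cn2ccc(NC(=O)c3ccccc3)nc2=O)C(OCc2ccccc2)=C1OCc1ccccc1` reaches only the limit of this assay, giving > 100000 nM, which is a limit and not a number. Compound 3 `Nc1ncn(CCC2(N)OC(=O)C(OCc3ccccc3)=C2OCc2ccccc2)c(=O)n1` likewise stops at the limit, at > 100000 nM. Compound 2 `O=C1O/C(=C\Cn2c(=O)[nH]c(=O)[nH]c2=O)C(OCc2ccccc2)=C1OCc1ccccc1` stands with them: in this assay compound 2 gives > 100000 nM, again a limit rather than a number. All three values fall on (the limit of > 100000 nM in this assay, at which 3 of the 3 values shown sit), so nothing separates compound 2 from the others.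

Compound 4 `O=C1O/C(=C\Cn2ncc(=O)[nH]c2=O)C(OCc2ccccc2)=C1OCc1ccccc1` has not yet been measured. It differs from compound 2 in one place: a group of 8 heavy atoms (3 carbon, 3 nitrogen, 2 oxygen; one six-membered aromatic ring with 3 hetero atoms) in place of a group of 9 heavy atoms (3 carbon, 3 nitrogen, 3 oxygen; one six-membered aromatic ring with 3 hetero atoms), on a saturated chain carbon bound to a double-bonded chain carbon. For the measured compounds named here, no step between two measured compounds is available to gauge such a change, and with every measured value at the same limit there is no direction to follow. The expected change in this assay is a number no higher from compound 2 to compound 4 (the limit leaves the size open), nothing beyond the scatter. Compound 4 is therefore estimated at about 100000 nM, within 30000 nM to 300000 nM, and most likely reported once more as a limit rather than a number.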

Compound 4, half-maximal inhibitory concentration: 36500 nM
The estimate for compound 4 lay 2.7-fold (0.44 log units) above the measured number, and the stated range covers the measured number.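

For the compounds shown here, the change on the saturated chain carbon bound to a double-bonded chain carbon, a group of 8 heavy atoms in place of a group of 9 heavy atoms, is the first to register in this assay: it gives an at least 2.7-fold lower number from compound 2 to compound 4 (0.43 log units; beyond the scatter). So this position can move the read-out off the limit, and the entering ring, with 1 hydrogen-bond donor and 2 double bonds outside aromatic rings, gives a measurable number where the group that leaves does not. The true size of the step stays open because compound 2 sits at a limit and not at a number: the limit of > 100000 nM in this assay, at which 3 of the 4 values shown sit.

The compounds shown do not tell whether a methyl group or a fluorine on the entering ring would move the number further. Nor do they tell what a carboxylic acid or a longer chain at this place would do.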